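The source may report more compounds than this note shows. Statements on the series, on what has been measured and on what is new or still open speak of the compounds shown alone.

Compound 1 `CN1CCC=C(c2ccc(CN(C)Cc3ccccc3)cc2)C1`: > 50000 nM
Compound 2 `CC(C)CN(C)Cc1ccc(C2CCCN(C)C2)cc1`: > 50000 nM

Both entries come from an ADME assay on HL-60 cells (Homo sapiens) for cytotoxicity, read by MTT assay, with a stated time of 24 h; a higher number here means a weaker inhibitor, a lower number a stronger inhibitor. For compound 1, the entry > 50000 nM is a limit of the assay and not a number. For compound 2, the entry > 50000 nM is likewise a limit. Compound 2 therefore has no exact value and stands with compound 1 at the limit of > 50000 nM in this assay, at which 2 of the 2 values shown sit.

Compound 3 `CC(C)CCCN(C)Cc1ccc(C2CCCN(C)C2)cc1`, not yet measured, has isopentyl in place of isopropyl on a saturated chain carbon bound to an amine nitrogen. Within the data shown here, no measured step between compounds is available to size this change. With compound 2 reported as > 50000 nM, no step beyond the scatter is expected in either direction, and another limit is the likeliest report. The expected change is a step that the limit leaves unreadable from compound 2 to compound 3. For compound 3 the estimated value is 60000 nM, with an expected range from 30000 nM to 120000 nM.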

Compound 3, half-maximal inhibitory concentration: > 50000 nM
Compound 3 ended at the assay's limit; the forecaster's own chance of this, stated with the estimate: 85%; the middle value lies beyond the limit too.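

No step can be read between compound 2 and compound 3, since each entry is a limit and not a number. The compounds shown leave open at what concentration, if any, each of them would reach half-maximal inhibition in this assay.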